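A few compounds are considered here, and "the series" means these few. Any claim that something is new, unique, unknown or untested is made for them only; others in the source may bear on it.

Measured compounds:
Compound 1 `N#C/C(=C\c1c(-c2ccccc2)[nH]c2ccccc12)C(=O)c1cccs1`: in a functional assay on DU-145 cells (Homo sapiens) for cytotoxicity, read by MTT assay, with a stated time of 96 h (on this read-out lower numbers stand for an effect already at smaller amounts and higher numbers for an effect only at larger amounts of compound), compound 1 gives 11000 nM.
Compound 2 `O=C(/C(=C\c1c(-c2ccccc2)[nH]c2ccccc12)C(=O)C(F)(F)F)c1ccco1`: in this assay compound 2 gives 9200 nM.
Compound 3 `COCCOC(=O)/C(C#N)=C/c1c(-c2ccccc2)[nH]c2ccccc12`: in this assay compound 3 gives 4200 nM.

Of these three numbers, compound 3 has the lowest, so its effect on the cells appears at the smallest amount; compound 2 is nearest to it and compound 1 furthest, and both gaps lie beyond the usual scatter. The compound not yet measured, compound 4 `N#C/C(=C\c1c(-c2ccccc2)[nH]c2ccccc12)C(=O)c1ccc(Cl)cc1`, differs from compound 3 in a single place: 4-chlorophenyl in place of 2-methoxyethoxy on a carbonyl carbon.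

For the measured compounds named here, only one measured step speaks to a change of this kind, the one in which thiophen-2-yl on the carbonyl carbon gave way to 2-methoxyethoxy: a 2.6-fold lower number from compound 1 to compound 3 (0.42 log units; beyond the scatter). Compound 4 takes the reverse road, putting a ring, here 4-chlorophenyl, back in place of 2-methoxyethoxy. Compound 2 differs from compound 3 in more than one place, so its value cannot be read as a clean step. On this basis a modest rise in the number is expected in this assay, of about the size seen before. Compound 4 is therefore expected to give 9500 nM, with a likely range from 4500 nM to 20000 nM. The expected step is a 2.3-fold higher number from compound 3 to compound 4 (0.35 log units; beyond the scatter).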

Compound 4, half-maximal effective concentration: 11000 nM
Compound 4: middle estimate off by 1.2-fold (0.06 log units), on the low side; the measured number falls inside the stated range.
By their numbers in this assay, from the lowest: compound 3; then compounds 2, 1 and 4 (each within the scatter of the next).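

In this assay, placing 4-chlorophenyl on the carbonyl carbon where 2-methoxyethoxy stood gives a 2.6-fold higher number from compound 3 to compound 4 (0.42 log units; beyond the scatter), so a second ring now lines up with the thiophen-2-yl of the earlier step, and the difference from the open chain no longer rests on a single ring. The two rings themselves cannot be told apart in this assay: 4-chlorophenyl in place of thiophen-2-yl gives no change at the digits printed from compound 1 to compound 4 (within the scatter), even though one ring is six-membered and carries chlorine. Among the three groups compared at this place, the measured gap therefore lies between the 2-methoxyethoxy chain and either ring, not between the two rings, although this rests on only these three compounds.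

The data shown give no information on why the chain and the rings differ in this way. From the compounds shown here alone, it remains open whether a longer chain, an amine or a carboxylic acid on this carbonyl carbon would keep the number of compound 3 or lower it further, and whether a ring carrying an amine would behave like the two rings seen here.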